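From Ethyl to Butyl on a Shared Core

The source may report more compounds than this note shows. Statements on the series, on what has been measured and on what is new or still open speak of the compounds shown alone.

Among the measured compounds shown here, compound 2 `CCOC(=O)Nc1ccc([Se]C#N)cc1` is one of two compounds measured so far in an ADME assay on 184B5 cells (Homo sapiens) for cytotoxicity, read by MTT assay, with a stated time of 72 h (a higher number here means a weaker inhibitor of growth, a lower number a stronger inhibitor of growth), where compound 2 gives 5500 nM. The other, compound 1 `C=CCOC(=O)Nc1ccc([Se]C#N)cc1`, gives 5000 nM in this assay, and the step of a 1.1-fold higher number from compound 1 to compound 2 (0.04 log units; within the scatter) shows that the two numbers sit within the scatter of each other, so neither can be called the stronger. Compound 3 `CCCCOC(=O)Nc1ccc([Se]C#N)cc1` is not yet measured. It differs from compound 2 in one place: ethyl in place of hydrogen on a saturated chain carbon, two bonds along the chain from an oxygen next to a carbonyl group. For the measured compounds named here, the only measured step, an exchange of methyl for vinyl, bears on this change just loosely, yet it shows that a small alteration of this chain left the number within the scatter. Lacking any measured step that lengthens the chain, the expectation for compound 3 is a step of no change at the digits printed from compound 2 to compound 3 (within the scatter), meaning nothing beyond the scatter. Compound 3 is therefore estimated at 5500 nM, with a range from 2500 nM to 12000 nM.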

Compound 3, concentration for 50% growth inhibition in the 184B5 assay: 5300 nM
Compound 3: middle estimate off by 1.0-fold (0.02 log units), on the high side; the range from low to high includes it.
By their numbers in the 184B5 assay, from the lowest: compounds 1, 3 and 2 (each within the scatter of the next).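

In the 184B5 assay the longer chain gives a 1.0-fold lower number from compound 2 to compound 3 (0.02 log units; within the scatter), and propyl in place of vinyl gives a 1.1-fold higher number from compound 1 to compound 3 (0.03 log units; within the scatter), so at this position a chain as long as butyl leaves the number for growth inhibition within the scatter. In a physicochemical assay, with a stated time of 6 min, tested at 0.1 mg/mL (on this read-out higher numbers stand for more inhibition at the one concentration tested (going by the name of the read-out) and lower numbers for less inhibition), compound 2 gives 26.3% and compound 3 gives 12.6%. In the physicochemical assay this is a number 13.7 percentage points lower from compound 2 to compound 3 (beyond the scatter), so the change from ethyl to butyl, which cannot be read in the cell assay, does register on this second read-out, though only modestly.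

The compounds shown leave open whether a much longer chain, or a chain ending in an amine or a carboxylic acid, would shift the number in the 184B5 assay. They also leave open what lies behind the lower percentage.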